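Taking One Fluoro from a Compound at the Limit

The source may hold more compounds than are shown below. What is called first, only, known or untested is meant among the compounds shown, and "the series" means these compounds.

In a functional assay on CCRF-CEM cells (Homo sapiens) for cytotoxicity, in the presence of a further agent that is not named here (on this read-out lower numbers stand for stronger inhibition and higher numbers for weaker inhibition), compound 1 (`COC(=O)c1ccc(CN(CCCc2c(N)nc(N)nc2O)c2cc(F)cc(F)c2[N+](=O)[O-])cc1`) shows > 100000 nM as a limit, not a number. Compound 3 (`Nc1nc(N)c(CCCN(Cc2ccc(NC(CCC(=O)O)C(=O)O)cc2)c2cc(F)cc(F)c2[N+](=O)[O-])c(O)n1`) shows > 100000 nM as a limit too. Compound 2 (`CC(C)(C)OC(=O)CCC(Nc1ccc(CN(CCCc2c(N)nc(N)nc2O)c2cc(F)cc(F)c2[N+](=O)[O-])cc1)C(=O)OC(C)(C)C`) alone gives a number, at 7700 nM in this set. Compound 1 thus stands at the limit of > 100000 nM in this assay, at which 2 of the 3 values shown sit, in this series.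

Compound 4 (`COC(=O)c1ccc(CN(CCCc2c(N)nc(N)nc2O)c2cc(F)ccc2[N+](=O)[O-])cc1`) carries hydrogen in place of fluoro on an aromatic carbon ortho to a nitro group, so 3,5-difluoro-2-nitrophenyl becomes 5-fluoro-2-nitrophenyl. Going by the values given here, the one measured step from compound 1 (a step that the two limits leave unreadable from compound 1 to compound 3) lies at another place and has no readable size, and no measured step touches this fluoro. With compound 1 at the limit of > 100000 nM in this assay no step beyond the scatter is expected, in either direction. The expected step is a number no higher from compound 1 to compound 4 (the limit leaves the size open) and a report of a limit alone is the likeliest outcome. For compound 4 the estimated value is 100000 nM with an expected range from 30000 nM to 300000 nM overall.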

Compound 4, half-maximal inhibitory concentration: 30000 nM
Compound 4: middle estimate off by 3.3-fold (0.52 log units), on the high side; measured number inside the range.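

Taking away this one fluoro, ortho to a nitro group, gives an at least 3.3-fold lower number from compound 1 to compound 4 (0.52 log units; beyond the scatter) in this assay, so a position that no earlier step touched does bear on the read-out. Going by these compounds alone, the one earlier step lay at another place and cannot be read, with limits at both its ends, which makes this the first readable single change. Its size stays open on one side, because compound 1 carries a limit and not a number: the limit of > 100000 nM in this assay, at which 2 of the 4 values shown sit.

The compounds shown leave open whether hydrogen in place of this fluoro does the same in compound 3, with its (1,3-dicarboxypropyl)amino group, or in compound 2, with its two tert-butyl esters. They also leave open what a chloro, a methoxy or an amine would give at this position in place of the fluoro.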